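Alkyl versus 2-fluorophenyl on the triazole: predicting compound 4

The source may hold more compounds than are shown below. What is called first, only, known or untested is meant among the compounds shown, and "the series" means these compounds.

Measured so far in an ADME assay on HeLa cells (Homo sapiens) for cytotoxicity, read by sulforhodamine B assay, with a stated time of 48 h, tested at 10 uM; a higher number here means more inhibition at the concentration tested (going by the name of the read-out), a lower number less inhibition:
compound 1, `CCCCCCc1cn(C(c2ccccc2)c2cc3cc(Br)ccc3nc2OC)nn1`, gives -0.97%
compound 2, `CCCCc1cn(C(c2ccccc2)c2cc3cc(Br)ccc3nc2OC)nn1`, gives -2.87%
compound 3, `COc1nc2ccc(Br)cc2cc1C(c1ccccc1)n1cc(-c2ccccc2F)nn1`, gives 14.1%

Compound 3 stands highest of the three numbers in this assay; compound 1 lies a number 15.1 percentage points higher from compound 1 to compound 3 (beyond the scatter) behind it, and compound 2 lies a number 17 percentage points higher from compound 2 to compound 3 (beyond the scatter) behind it, both beyond the scatter. Between the two alkyl compounds themselves the step of a number 1.9 percentage points lower from compound 1 to compound 2 (within the scatter) is within the scatter, so hexyl and butyl on that ring carbon read alike.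

Compound 4, `CCCc1cn(C(c2ccccc2)c2cc3cc(Br)ccc3nc2OC)nn1`, differs from compound 3 by propyl in place of 2-fluorophenyl on an aromatic carbon. The relevant comparisons are the two alkyl-to-aryl steps, a number 15.1 percentage points higher from compound 1 to compound 3 (beyond the scatter) and a number 17 percentage points higher from compound 2 to compound 3 (beyond the scatter), which point the same way and are of similar size; the step from compound 3 to compound 4 runs this change in reverse, with a third alkyl chain in place of the aryl group. Since hexyl and butyl gave the same reading within the scatter, propyl is expected to behave like them rather than like 2-fluorophenyl.

For compound 4 a step of a number 16.1 percentage points lower from compound 3 to compound 4 (beyond the scatter) in this assay is therefore expected, downward and beyond the scatter. Compound 4 is estimated at -2%, with a range from -12% to 8%.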

Compound 4, a percentage reported as inhibition, at one concentration (the size of the read-out at that concentration, not a potency): -2.25%
Compound 4: the middle estimate sits 0.3 percentage points above what was measured, within the range that was stated.
By their numbers in this assay, from the lowest: compounds 2, 4 and 1 (each within the scatter of the next); then compound 3.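

Notes on the substituent at this aromatic carbon of the triazole-bearing series, read in this assay: with propyl in place of 2-fluorophenyl the reading falls by a similar amount to the earlier alkyl-to-aryl comparisons, a number 16.4 percentage points lower from compound 3 to compound 4 (beyond the scatter) and so the gap to 2-fluorophenyl is not confined to the longer chains. Within the alkyl set, the steps of a number 0.6 percentage points higher from compound 2 to compound 4 (within the scatter) and a number 1.3 percentage points lower from compound 1 to compound 4 (within the scatter) leave propyl, butyl and hexyl reading alike, so these compounds show no dependence on chain length over this range, and the split at this position runs between the three alkyl chains on one side and the single aryl group on the other. Nothing at hand bears on why 2-fluorophenyl separates from the alkyl chains.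

With 2-fluorophenyl as the only aryl group shown, it stays open whether the higher reading belongs to the aromatic ring or to its fluorine, a question that plain phenyl or 4-fluorophenyl would address. Also open, going by these compounds, is whether any alkyl-type group departs from the flat readings, such as methyl, a much longer chain, or a chain ending in an amine or a carboxylic acid.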